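Moving the amino group: from compound 3 to compound 4

This account rests on a few compounds, and the source may have more. Where it says the series, first, only, none or still open, it means among the compounds named here.

Compounds measured so far:
Compound 1, `Nc1ccc(Nc2nc3ccccc3nc2S(=O)(=O)c2ccc(Br)cc2)cc1`, 2330 nM in a functional assay on PC-3 cells (Homo sapiens) for cytotoxicity, read by MTT assay, with a stated time of 72 h; on this read-out higher numbers stand for weaker inhibition and lower numbers for stronger inhibition
Compound 2, `Nc1cccc(Nc2nc3ccccc3nc2S(=O)(=O)c2ccc(Br)cc2)c1`, 9010 nM
Compound 3, `Nc1ccc(Nc2nc3ccccc3nc2S(=O)(=O)c2ccc(F)cc2)cc1`, 2050 nM

The three measured compounds share one core and differ at two places. Between compound 1 and compound 2 the difference is 3-aminophenyl in place of 4-aminophenyl on a nitrogen on an aromatic ring. This change gave a 3.9-fold higher number from compound 1 to compound 2 (0.59 log units; beyond the scatter). Between compound 1 and compound 3 the cores differ by fluoro in place of bromo on an aromatic carbon, and this gave a 1.1-fold lower number from compound 1 to compound 3 (0.06 log units; within the scatter), so compound 1 and compound 3 cannot be told apart on this read-out.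

Compound 4, `Nc1cccc(Nc2nc3ccccc3nc2S(=O)(=O)c2ccc(F)cc2)c1`, has not yet been measured in this assay. It differs from compound 3 by 3-aminophenyl in place of 4-aminophenyl on a nitrogen on an aromatic ring. The place is the same as that of the change from compound 1 to compound 2, word for word, so this is the same change made on a core that differs only by the fluoro in place of bromo.

Within the data shown here, since the two cores gave numbers within the usual scatter of each other, the step from compound 3 to compound 4 is expected to be of the size of the one from compound 1 to compound 2: an estimated 3.9-fold higher number from compound 3 to compound 4 (0.59 log units; beyond the scatter), resting on a 3.9-fold higher number from compound 1 to compound 2 (0.59 log units; beyond the scatter). Compound 4 is therefore expected to give about 8000 nM, with a likely range from 3500 nM to 18000 nM.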

Compound 4, half-maximal inhibitory concentration: 1980 nM
Compound 4: the middle estimate sits 4.0-fold (0.61 log units) above what was measured; measured number below the stated range.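

On the core bearing fluoro, 3-aminophenyl in place of 4-aminophenyl gave a 1.0-fold lower number from compound 3 to compound 4 (0.02 log units; within the scatter) in this assay, so the step seen with bromo did not carry over to this core: the same change on two cores in this assay, a 3.9-fold higher number (0.59 log units; beyond the scatter) from compound 1 to compound 2 and a 1.0-fold lower number (0.02 log units; within the scatter) from compound 3 to compound 4, 4.0-fold (0.60 log units) apart, beyond the scatter of two such steps

Read along the other change, fluoro in place of bromo gave a 4.6-fold lower number from compound 2 to compound 4 (0.66 log units; beyond the scatter), a step that appears only with the 3-aminophenyl group and not with the 4-aminophenyl group: the same change on two cores in this assay, a 1.1-fold lower number (0.06 log units; within the scatter) from compound 1 to compound 3 and a 4.6-fold lower number (0.66 log units; beyond the scatter) from compound 2 to compound 4, 4.0-fold (0.60 log units) apart, beyond the scatter of two such steps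

Within these four compounds, then, the effect of each change depends on the group present at the other place, so neither step can be carried from one core to the other; with a single pair of cores and one value for each compound, this does not show why the two changes interact, nor whether the same holds elsewhere in the series.

The compounds shown leave open whether chloro or methoxy in place of the halogen would follow compound 2 or compound 4 when paired with the 3-aminophenyl group. They also leave open whether a hydroxyl or a dimethylamino group in place of the amino group would show the same dependence on the halogen.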